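Swapping the para methoxy for bromine in compound 4

This account rests on a few compounds, and the source may have more. Where it says the series, first, only, none or still open, it means among the compounds named here.

Compound 3 `COc1ccc(OCCCON2C(N)=NC(N)=NC23CCOCC3)cc1` gives 1670 nM in a functional assay on HL-60 cells (Homo sapiens) for antiproliferative activity, read by MTT assay, with a stated time of 72 h (a lower number here means a stronger inhibitor, a higher number a weaker inhibitor), the highest of the three numbers seen so far; compound 1 `NC1=NC2(CCOCC2)N(OCCCOc2ccc(Cl)cc2)C(N)=N1` gives 330 nM and compound 2 `NC1=NC2(CCOCC2)N(OCCCOc2ccccc2Br)C(N)=N1` gives 610 nM, both steps to compound 3 lying beyond the scatter. Compound 4 `NC1=NC2(CCOCC2)N(OCCCOc2ccc(Br)cc2)C(N)=N1` differs from compound 3 by bromo in place of methoxy on an aromatic carbon. Among the compounds with values here, the closest precedent is the reverse change: a 5.1-fold higher number from compound 1 to compound 3 (0.70 log units; beyond the scatter), so a step of roughly that size in the opposite direction is expected here, while a 2.7-fold higher number from compound 2 to compound 3 (0.44 log units; beyond the scatter) points the same way. Compound 4 is therefore expected to land near compound 1, at an estimated 380 nM (range 150 nM to 950 nM), which would mean an expected step of a 4.4-fold lower number from compound 3 to compound 4 (0.64 log units; beyond the scatter).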

Compound 4, half-maximal inhibitory concentration: 310 nM
For compound 4 the middle estimate is 1.2-fold (0.09 log units) above the measured one; the range from low to high includes it.
By their numbers in this assay, from the lowest: compounds 4, 1 and 2 (each within the scatter of the next); then compound 3.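

In this assay bromo and chloro on this aromatic carbon cannot be told apart, with a 1.1-fold lower number from compound 1 to compound 4 (0.03 log units; within the scatter) inside the scatter, whereas methoxy stands apart, with a 5.4-fold lower number from compound 3 to compound 4 (0.73 log units; beyond the scatter) beyond it. Moving the bromo on the ring also gives no readable change, since a 2.0-fold lower number from compound 2 to compound 4 (0.29 log units; within the scatter) lies within the scatter too. No measured evidence accounts for the gap left by methoxy. On these data alone, whether fluoro, an amine or a carboxylic acid on this aromatic carbon would fall with bromo and chloro or with methoxy stays open.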